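The source may hold more compounds than are shown below. What is called first, only, known or untested is meant among the compounds shown, and "the series" means these compounds.

Measured so far in a functional assay (strain AB) with Danio rerio as the target, read by microscopy, with a stated time of 1 h; on this read-out higher numbers stand for an effect only at larger amounts of compound and lower numbers for an effect already at smaller amounts:
Compound 1 `CCN1CCc2c(sc(NC(=O)Nc3ccc(Br)cc3)c2C(N)=O)C1` gives 3130 nM.
Compound 2 `CCN1CCc2c(sc(NC(=O)Nc3ccc(Cl)cc3)c2C(N)=O)C1` gives 3120 nM.
Compound 3 `CCN1CCc2c(sc(NC(=O)Nc3ccc(I)cc3)c2C(N)=O)C1` gives 1620 nM.

Compound 3 has the lowest number of the three, but its steps from compound 2 a 1.9-fold lower number from compound 2 to compound 3 (0.28 log units; within the scatter) and from compound 1 a 1.9-fold lower number from compound 1 to compound 3 (0.29 log units; within the scatter) both lie within the scatter, so no order among the three can be claimed. Compound 4 `CCN1CCc2c(sc(NC(=O)c3ccccc3)c2C(N)=O)C1` is not yet measured. It differs from compound 3 in one place: phenyl in place of (4-iodophenyl)amino on a carbonyl carbon. For the measured compounds named here, none of the measured steps bears directly on this change: a 1.0-fold lower number from compound 1 to compound 2 (0.00 log units; within the scatter), a 1.9-fold lower number from compound 1 to compound 3 (0.29 log units; within the scatter) and a 1.9-fold lower number from compound 2 to compound 3 (0.28 log units; within the scatter) only swap one halogen for another on the aromatic ring, whereas here the whole (4-iodophenyl)amino group leaves and a plain phenyl enters. Going by the values given here, with no precedent in the data, the step of a 3.1-fold higher number from compound 3 to compound 4 (0.49 log units; beyond the scatter) is estimated as a modest rise in the number, with wide uncertainty. Compound 4 is expected to give about 5000 nM, within a range from 1500 nM to 16000 nM.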

Compound 4, half-maximal effective concentration: > 25000 nM
Compound 4 was reported as a limit (the forecaster's own chance of this, stated with the estimate: 15%); middle value at least 5.0-fold (0.69 log units) from the limit.
By their numbers in this assay, from the lowest: compounds 3, 2 and 1 (each within the scatter of the next). At a limit, above all of these: compound 4.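

In this assay compound 4 carries a limit, not a number: the limit of > 25000 nM in this assay, at which 1 of the 4 values shown sits. Swapping one halogen for another stayed within the scatter, whereas replacing the whole substituted amino group on the carbonyl carbon with phenyl is beyond it: an at least 15-fold higher number from compound 3 to compound 4 (1.18 log units; beyond the scatter), an at least 8.0-fold higher number from compound 2 to compound 4 (0.90 log units; beyond the scatter) and an at least 7.9-fold higher number from compound 1 to compound 4 (0.90 log units; beyond the scatter). This place on the carbonyl carbon is therefore far more sensitive to this change than the halogen swaps suggested.

As far as these compounds go, the change removes the nitrogen and the halogen together, so their separate shares stay open. Phenylamino and 4-iodophenyl on the same carbonyl carbon would tell them apart.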